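A few compounds are considered here, and "the series" means these few. Any claim that something is new, unique, unknown or untested is made for them only; others in the source may bear on it.

Compound 1 `O=C(CSc1nnc(-c2ccncc2)o1)N/N=C/c1ccc(Cl)cc1`: 15300 nM
Compound 2 `O=C(CSc1nnc(-c2ccncc2)o1)N/N=C/c1ccc([N+](=O)[O-])cc1`: 31800 nM
Compound 3 `Cc1ccc(/C=N/NC(=O)CSc2nnc(-c3ccncc3)o2)cc1`: 14700 nM

In a functional assay on MCF7 cells (Homo sapiens) for cytotoxicity, read by MTT assay, with a stated time of 48 h (on this read-out higher numbers stand for weaker inhibition and lower numbers for stronger inhibition), compound 3 and compound 1 give numbers that lie within the scatter of each other, and both lie below compound 2. The step from compound 1 to compound 3 is a 1.0-fold lower number from compound 1 to compound 3 (0.02 log units; within the scatter), while compound 2 sets itself apart with a 2.1-fold higher number from compound 1 to compound 2 (0.32 log units; beyond the scatter) and a 2.2-fold lower number from compound 2 to compound 3 (0.34 log units; beyond the scatter).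

Compound 4 `O=C(CSc1nnc(-c2ccncc2)o1)N/N=C/c1ccccc1O` differs from compound 3 in one place: 2-hydroxyphenyl in place of 4-methylphenyl on a carbon with a double bond to nitrogen. For the measured compounds named here, no measured step exchanges a 4-methylphenyl for a 2-hydroxyphenyl, so the steps that bear on this change are those that alter the substituent on the same aryl ring. Of these, a 1.0-fold lower number from compound 1 to compound 3 (0.02 log units; within the scatter) stays within the scatter, and only a 2.2-fold lower number from compound 2 to compound 3 (0.34 log units; beyond the scatter) reaches a modest size. The entering group brings one hydrogen-bond donor and one acceptor, which none of the three measured groups did, so the comparison is loose. On this basis the expected step is a 1.0-fold higher number from compound 3 to compound 4 (0.01 log units; within the scatter), not beyond the scatter in either direction. Compound 4 is therefore estimated at 15000 nM, with a range from 6000 nM to 40000 nM.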

Compound 4, half-maximal inhibitory concentration: 4750 nM
Estimate against measurement, compound 4: 3.2-fold (0.50 log units) above, outside the stated range (below it).
By their numbers in this assay, from the lowest: compound 4; then compounds 3 and 1 (each within the scatter of the next); then compound 2.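

In this assay, the group on the carbon with a double bond to nitrogen now proves able to shift the number well beyond the scatter: 2-hydroxyphenyl gives a 3.1-fold lower number from compound 3 to compound 4 (0.49 log units; beyond the scatter), a 3.2-fold lower number from compound 1 to compound 4 (0.51 log units; beyond the scatter) and a 6.7-fold lower number from compound 2 to compound 4 (0.83 log units; beyond the scatter). The earlier exchanges among 4-chlorophenyl, 4-nitrophenyl and 4-methylphenyl had left compound 1 and compound 3 within the scatter of each other, while compound 4 now stands as the most potent of the four, with its steps to all the others beyond the scatter. No measurement at hand accounts for this shift.

The compounds shown do not tell whether the shift belongs to the hydroxyl itself or to the whole 2-hydroxyphenyl group. A methoxy or an amine in place of the hydroxyl on that ring would bear on this question.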